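A few compounds are considered here, and "the series" means these few. Any claim that something is new, unique, unknown or untested is made for them only; others in the source may bear on it.

In a functional assay on HEK293 cells for activation of melanin-concentrating hormone receptor 1 (Homo sapiens), read by inositol phosphate accumulation (on this read-out higher numbers stand for an effect only at larger amounts of compound and lower numbers for an effect already at smaller amounts), compound 1 `Nc1cc(C2CCCC2)nc2ccc(NC(=O)/C=C/c3ccc(C(F)(F)F)cc3)cc12` gives 68 nM, and compound 2 `CCCc1cc(N)c2cc(NC(=O)/C=C/c3ccc(CC)cc3)ccc2n1` gives 160 nM, the higher of the two numbers, a gap that lies beyond the usual scatter. Compound 3 `CCCc1cc(N)c2cc(NC(=O)/C=C/c3ccccc3Cl)ccc2n1` differs from compound 2 in one place: 2-chlorophenyl in place of 4-ethylphenyl on a double-bonded chain carbon bound to a double-bonded chain carbon. Going by the values given here, no measured pair shows the size of such a step, so the expectation rests on the two values alone; in this assay a small rise for compound 3, not far beyond the scatter, is expected. Compound 3 is therefore expected to give 250 nM, with a range from 80 nM to 800 nM. The estimated step is a 1.6-fold higher number from compound 2 to compound 3 (0.19 log units; within the scatter).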

Compound 3, half-maximal effective concentration: 500 nM
Compound 3: the middle estimate sits 2.0-fold (0.30 log units) below what was measured; measured number inside the range.
By their numbers in this assay, from the lowest: compound 1; then compound 2; then compound 3.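

In this assay the change to 2-chlorophenyl in place of 4-ethylphenyl gives a 3.1-fold higher number from compound 2 to compound 3 (0.49 log units; beyond the scatter) so the group at this position does affect the amount of compound needed. Going by these compounds alone, this is the first comparison here in which only one place differs, and the 4-ethylphenyl compound needs the smaller amount of the two. Nothing measured here explains the shift. The swap alters both the substituent and its place on the ring, so the compounds shown cannot separate those two changes. A 4-chlorophenyl group would test this, while a 4-aminophenyl group would show how an amine behaves here.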